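The source may report more compounds than this note shows. Statements on the series, on what has been measured and on what is new or still open speak of the compounds shown alone.

Measured compounds:
- compound 1, `COc1cc2c(cc1OC)C(CC(=O)O)CC2`, 23.9%
- compound 2, `COc1cc2c(cc1OC)C(CC(=O)Nc1cccc(C)c1)CC2`, 40.6%
- compound 3, `COc1cc2c(cc1OC)C(CC(=O)Nc1ccc([N+](=O)[O-])cc1)CC2`, 37.5%

In a functional assay on the whole organism (strain Wistar) for inhibition, with Rattus norvegicus as the target, read by paw edema, with a stated time of 4 h, at a dose of 100 mg/kg (a lower number here means less inhibition, a higher number more inhibition at the dose given (going by the name of the read-out)), compound 2 gives the highest of the three numbers. The gap to compound 3 is within the usual scatter, so the two cannot be ranked against each other; the gap to compound 1 is beyond the scatter.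

Compound 4, `COc1cc2c(cc1OC)C(CC(=O)Nc1ccncc1)CC2`, is the next compound to be measured. It differs from compound 2 in one place: pyridin-4-yl in place of 3-methylphenyl on an amide-type nitrogen.

Among the compounds with values here, only one step between measured compounds is known, a number 16.7 percentage points higher from compound 1 to compound 2 (beyond the scatter), which turned the free acid into an aryl amide. That step changes the amide itself, not the group on the amide nitrogen, so it bears only loosely on the change from compound 2 to compound 4. What the values of compound 2 and compound 3 show is that two different substituted phenyl groups on the amide nitrogen give numbers within the scatter of each other. Swapping to a pyridin-4-yl is another change of that kind, so no step beyond the scatter is expected in this assay, with the estimated step being a number 4.6 percentage points lower from compound 2 to compound 4 (within the scatter).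

Compound 4 is therefore expected to give about 36%, in the range 24% to 48%.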

Compound 4, a percentage reported as inhibition, in the whole organism at one dose (the size of the read-out at that dose, not a potency): 45.3%
For compound 4 the middle estimate is 9.3 percentage points below the measured one; the range from low to high includes it.
By their numbers in this assay, from the lowest: compound 1; then compounds 3, 2 and 4 (each within the scatter of the next).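

In this assay, putting pyridin-4-yl on the amide-type nitrogen in place of 3-methylphenyl gives a number 4.7 percentage points higher from compound 2 to compound 4 (within the scatter), so this position accepts an aromatic ring containing a nitrogen as well as one of carbon only, with no difference that can be told apart from the scatter. The gain over the free acid also holds for this new amide, at a number 21.4 percentage points higher from compound 1 to compound 4 (beyond the scatter), so that gain is not tied to the 3-methylphenyl group of compound 2. Nothing available explains why these two rings read alike in this test on rats.

As far as these compounds go, it remains open whether an aromatic ring is needed on the amide-type nitrogen at all, or whether a cyclohexyl group or a short alkyl chain there would give a similar number. Also open, from the compounds shown here alone, is whether moving the ring nitrogen, as in pyridin-3-yl, would matter, and how these amides compare in potency, as each number describes the size of the effect at one dose only.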